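Halogen and pseudohalogen swaps on the aryl ring of the series

This account rests on a few compounds, and the source may have more. Where it says the series, first, only, none or still open, it means among the compounds named here.

Of the compounds shown here, three of one shared core have been measured. Compound 1 `Cc1cnnc(C#Cc2cccc(Cl)c2)n1` gives 4.2 nM in a functional assay on CHO-K1 cells for antagonist activity at metabotropic glutamate receptor 5 (Homo sapiens), read by calcium flux; on this read-out lower numbers stand for stronger inhibition and higher numbers for weaker inhibition. Compound 2 `Cc1cnnc(C#Cc2cccc(F)c2)n1` gives 96 nM in this assay, and compound 3 `Cc1cnnc(C#Cc2cccc(C(F)(F)F)c2)n1` gives 85 nM. Compound 3 stands second highest of the three numbers: its nearest neighbour is compound 2, within the scatter, and its furthest is compound 1, beyond the scatter, as the step of a 20-fold higher number from compound 1 to compound 3 (1.31 log units; beyond the scatter) shows.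

The next compound, compound 4 `Cc1cnnc(C#Cc2cccc(C#N)c2)n1`, carries the change (cyano in place of trifluoromethyl on an aromatic carbon). Among the compounds with values here, no measured step involves cyano, so the bearing steps are indirect. The two large steps, a 23-fold higher number from compound 1 to compound 2 (1.36 log units; beyond the scatter) and a 20-fold higher number from compound 1 to compound 3 (1.31 log units; beyond the scatter), both arise when chloro leaves; the step of a 1.1-fold lower number from compound 2 to compound 3 (0.05 log units; within the scatter) shows that fluoro and trifluoromethyl at this position give numbers that cannot be told apart. Nothing in the set says whether cyano will behave like the chloro of compound 1 or like the fluoro and trifluoromethyl of compounds 2 and 3. The expectation for compound 4 is therefore a small move, a 2.1-fold lower number from compound 3 to compound 4 (0.33 log units; beyond the scatter), not clearly beyond the scatter. The estimate for compound 4 in this assay is 40 nM, with a range from 10 nM to 200 nM.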

Compound 4, half-maximal inhibitory concentration: 52 nM
The estimate for compound 4 lay 1.3-fold (0.11 log units) below the measured number; the range from low to high includes it.
By their numbers in this assay, from the lowest: compound 1; then compounds 4, 3 and 2 (each within the scatter of the next).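

Working notes: in this assay, cyano falls in with the two groups already tested in place of chloro, since a 1.6-fold lower number from compound 3 to compound 4 (0.21 log units; within the scatter) and a 1.8-fold lower number from compound 2 to compound 4 (0.27 log units; within the scatter) both stay within the scatter, while a 12-fold higher number from compound 1 to compound 4 (1.09 log units; beyond the scatter) is large. The earlier compounds shown here showed that fluoro and trifluoromethyl could not be told apart at this aromatic carbon, and it now appears that a third replacement, one that brings a triple bond and a hydrogen-bond acceptor, also gives a number that cannot be told apart from theirs. Among the four compounds, chloro alone stands apart with the lowest number, its steps to compounds 2, 3 and 4 all lying beyond the scatter, and no compound shown goes against this pattern. No measured data here bear on why chloro differs from the other three groups.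

The compounds shown leave open whether a bromo, methyl or methoxy group on this aromatic carbon would give a number close to that of compound 1 or close to those of compounds 2, 3 and 4. They also leave open whether the gap between chloro and cyano would persist if the methyl on the shared core were replaced by an amine.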